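A few compounds are considered here, and "the series" means these few. Any claim that something is new, unique, unknown or untested is made for them only; others in the source may bear on it.

Compound 1 `CCCNC(=O)Nc1ccc(C(C)C)cc1` gives 54000 nM in a functional assay on K562 cells (Homo sapiens) (on this read-out lower numbers stand for stronger inhibition and higher numbers for weaker inhibition), the highest of the two numbers recorded so far, with compound 2 `CCCNC(=O)Nc1ccc(C(C)(C)C)cc1` closest to it at 30000 nM. Within the data shown here, the only measured step, a 1.8-fold lower number from compound 1 to compound 2 (0.26 log units; within the scatter), changes the group on the aromatic side of the shared core and stays within the scatter. Compound 3 `CNC(=O)Nc1ccc(C(C)C)cc1` is reached from compound 1 by a change on the other side of the urea: hydrogen in place of ethyl on a saturated chain carbon bound to an amide-type nitrogen. Among the measured compounds shown here, no measured step touches that place, so the one step recorded bears only indirectly, and its small size gives no direction to lean on. The author therefore expects compound 3 to land near compound 1, with an estimated change of a 1.1-fold higher number from compound 1 to compound 3 (0.05 log units; within the scatter) in this assay, not beyond the scatter. The estimate for compound 3 is 60000 nM, with a range of 20000 nM to 180000 nM.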

Compound 3, half-maximal inhibitory concentration: 198000 nM
The estimate for compound 3 lay 3.3-fold (0.52 log units) below the measured number; the whole stated range lies below it.
By their numbers in this assay, from the lowest: compounds 2 and 1 (each within the scatter of the next); then compound 3.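

Among these compounds, the side of the shared core that no earlier step touched proves not to be silent in this assay: hydrogen in place of ethyl on a saturated chain carbon bound to an amide-type nitrogen, which is propyl to methyl, gives a 3.7-fold higher number from compound 1 to compound 3 (0.56 log units; beyond the scatter). Among the compounds shown here, this modest change is the first step beyond the scatter, whereas the change on the aromatic side, a 1.8-fold lower number from compound 1 to compound 2 (0.26 log units; within the scatter), does not separate its two compounds. Nothing at hand accounts for the size of the new step.

With only propyl and methyl at this place, the compounds shown cannot tell whether the number keeps falling as the chain grows. As far as these compounds go, a longer chain such as butyl, a propyl chain ending in an amine or a carboxylic acid, and the same change on the core of compound 2 all remain open.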